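Swapping the Amide Substituent on the Shared Core

The source may hold more compounds than are shown below. What is called first, only, known or untested is meant among the compounds shown, and "the series" means these compounds.

Compound 1 `O=C(NCc1ccccc1)c1c(O)c2cccnc2n(-c2ccccc2)c1=O`: 11.3%
Compound 2 `COc1ccccc1NC(=O)c1c(O)c2cccnc2n(-c2ccccc2)c1=O`: -10.1%

Going by the values given here, compound 2 stands lowest of the two numbers in a functional assay on the whole organism for inhibition, with Rattus norvegicus as the target, read by cytopathic effect and paw edema, at a dose of 100 mg/kg by the oral route; on this read-out lower numbers stand for less inhibition and higher numbers for more inhibition at the one dose given (going by the name of the read-out); the only measured step, a number 21.4 percentage points lower from compound 1 to compound 2 (beyond the scatter), separates it from compound 1. Compound 3 `O=C(Nc1cnccn1)c1c(O)c2cccnc2n(-c2ccccc2)c1=O` carries the change (pyrazin-2-yl in place of 2-methoxyphenyl on an amide-type nitrogen). That single step bears on it, since it also exchanges the group on the amide-type nitrogen, and it was modest. Among the compounds with values here, no step shows a pyrazin-2-yl group, so the direction is open; a change no larger than that step, in either direction, is expected, a number 12.1 percentage points higher from compound 2 to compound 3 (beyond the scatter). Compound 3 is therefore estimated at 2% in this assay, within -15% to 20%.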

Compound 3, a percentage reported as inhibition, in the whole organism at one dose (the size of the read-out at that dose, not a potency): 21.2%
Estimate against measurement, compound 3: 19.2 percentage points below; measured number outside the range, above it.
By their numbers in this assay, from the lowest: compound 2; then compounds 1 and 3 (each within the scatter of the next).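

In this assay the group on the amide-type nitrogen can shift the number widely: pyrazin-2-yl in place of 2-methoxyphenyl gives a number 31.3 percentage points higher from compound 2 to compound 3 (beyond the scatter) in a large step. Pyrazin-2-yl in place of benzyl gives a number 9.9 percentage points higher from compound 1 to compound 3 (within the scatter) and so leaves compound 1 and compound 3 indistinguishable here, with only compound 2 standing apart from both. Nothing available explains why this exchange moves the number.

On these data alone, it remains open whether an unsubstituted phenyl or a pyridin-2-yl group on this nitrogen would fall with compound 2 or with the other two compounds. Such a group would also help show whether the methoxy group or the ring itself sets compound 2 apart.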